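The source may report more compounds than this note shows. Statements on the series, on what has been measured and on what is new or still open speak of the compounds shown alone.

Working notes on the series. Two compounds of the shared core carry a measured value in an ADME assay on microsomes from liver (Rattus norvegicus) for metabolic stability, read by LC-MS, using NADPH, with a stated time of 30 min, tested at 1 uM; on this read-out lower numbers stand for a less stable compound and higher numbers for a more stable compound. Compound 1 `COC(=O)C1=C(Nc2ccccc2F)O/C(=C\c2c[nH]c3ncccc23)C1=O` gives 10% in this assay. For the measured compounds named here, compound 2 `COC(=O)C1=C(Nc2ccc(C)cc2C)O/C(=C\c2c[nH]c3ncccc23)C1=O` gives 30% in this assay, and the move a number 20 percentage points higher from compound 1 to compound 2 (beyond the scatter) is the only step so far, with the change from 2-fluorophenyl to 2,4-dimethylphenyl on the amine nitrogen. On the numbers shown, compound 2 stands highest of the two, with compound 1 the nearest and lower beyond the scatter.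

Compound 3 `COC(=O)C1=C(Nc2ccccc2Cl)O/C(=C\c2c[nH]c3ncccc23)C1=O` is not yet measured. It differs from compound 2 by 2-chlorophenyl in place of 2,4-dimethylphenyl on an amine nitrogen. Going by the values given here, this change undoes the one measured step in part: the 2,4-dimethylphenyl that came in from compound 1 leaves again, and a 2-chlorophenyl enters, which shares with compound 1 a single substituent in the 2-position, though the halogen is a different one. The step that bears on it is the gain of a number 20 percentage points higher from compound 1 to compound 2 (beyond the scatter), and the reverse direction is the expectation here. The 2-chlorophenyl that enters is not the same group as the 2-fluorophenyl of compound 1, and the expected size is set somewhat short of that step. Compound 3 is therefore expected to drop by a number 15 percentage points lower from compound 2 to compound 3 (beyond the scatter) in this assay, to an estimated 15% with a range from 4% to 35%.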

Compound 3, percent of the compound remaining: 58%
Compound 3: middle estimate off by 43 percentage points, on the low side; the measured number lies above the stated range.
By their numbers in this assay, from the lowest: compound 1; then compound 2; then compound 3.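

In this assay, for the compounds shown here, the aryl group on the amine nitrogen proves more sensitive than the one earlier step could show. The exchange of fluoro for chloro on an aromatic carbon, with the rest of the structure unchanged, gives a number 48 percentage points higher from compound 1 to compound 3 (beyond the scatter), the largest step in the series so far, while 2-chlorophenyl in place of 2,4-dimethylphenyl gives a number 28 percentage points higher from compound 2 to compound 3 (beyond the scatter), so the order among these three compounds does not follow the number of substituents on the phenyl group, as 2-fluorophenyl and 2-chlorophenyl stand at the two ends with 2,4-dimethylphenyl in the middle. Nothing at hand explains why the two halogens part so widely on this read-out.

Open, going by these compounds, is whether the gain seen with 2-chlorophenyl extends to 2-bromophenyl or 2-methylphenyl, which would show whether chloro itself or a wider set of groups carries it. Also open, on these data alone, is whether 2-chlorophenyl keeps its standing when the methyl ester of the shared core gives way to an amide or a carboxylic acid.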